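Notes on an ether substituent swap in a small series

The source may report more compounds than this note shows. Statements on the series, on what has been measured and on what is new or still open speak of the compounds shown alone.

Measured in an assay for inhibition of 15-hydroxyprostaglandin dehydrogenase [NAD(+)] (Homo sapiens), read by fluorescence and spectrophotometry; a lower number here means a stronger inhibitor, a higher number a weaker inhibitor:
compound 1 `O=C1N=C(O)S/C1=C\c1ccc(OCCC2CCCCC2)cc1Cl`: 13 nM
compound 2 `Cc1ncsc1CCOc1ccc(/C=C2\SC(=O)NC2=O)cc1Cl`: 5170 nM
compound 3 `O=C1NC(=O)/C(=C/c2ccc(Oc3cccc4c3CCCC4=O)c(Cl)c2)S1`: 71 nM

Compound 2 stands highest of the three numbers; compound 3 sits well below it and compound 1 lower still, both gaps beyond the scatter. Compound 4 `O=C1NC(=O)/C(=C/c2ccc(OCC3CC4CCC3C4)c(Cl)c2)S1` differs from compound 2 by a group of 7 heavy atoms (7 carbon; 2 five-membered non-aromatic rings of carbon only) in place of a group of 7 heavy atoms (5 carbon, 1 nitrogen, 1 sulfur; one five-membered aromatic ring with 2 hetero atoms), on a saturated chain carbon bound to an oxygen on an aromatic ring. Among the measured compounds shown here, no single-change step between measured compounds is available, so no exact step size is known. The expected step from compound 2 to compound 4 is a 100-fold lower number from compound 2 to compound 4 (2.01 log units; beyond the scatter), a large fall in the number and well beyond the scatter. This expectation rests on compound 1, which gives 13 nM with an ether built from saturated carbon rings only, and on compound 3 giving 71 nM. Compound 4 is estimated in this assay at 50 nM, within 10 nM to 300 nM.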

Compound 4, half-maximal inhibitory concentration: 165 nM
Estimate against measurement, compound 4: 3.3-fold (0.52 log units) below; the range from low to high includes it.
By their numbers in this assay, from the lowest: compound 1; then compound 3; then compound 4; then compound 2.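

With the heavy-atom count unchanged, swapping (4-methyl-1,3-thiazol-5-yl)methyl for the all-carbon group with 2 five-membered non-aromatic rings, on a saturated chain carbon bound to an oxygen on an aromatic ring, gives a 31-fold lower number from compound 2 to compound 4 (1.50 log units; beyond the scatter) in this assay. Among the compounds shown here, this is the first single-change step, and it shows that this position tolerates no free exchange of groups of equal heavy-atom count. Nothing available accounts for the size of this step.

One step cannot separate the loss of the ring nitrogen and sulfur from the change to saturated carbon rings. As far as these compounds go, how a phenyl group in the same place would compare remains open.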